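Swapping Methyl for Acetyl on a Piperazine Nitrogen

The compounds below may be only part of what the source reports. "The series", "measured", "known", "first", "only" and "open" are said of these compounds alone.

Measured so far:
- compound 1, `COc1cc(OC)c(Cl)c(-c2ccc3c(NC(=O)c4ccc(N5CCN(C)CC5)cc4)n[nH]c3n2)c1Cl`: 1.7 nM
- compound 2, `CCN1CCN(c2ccc(C(=O)Nc3n[nH]c4nc(-c5c(Cl)c(OC)cc(OC)c5Cl)ccc34)cc2)CC1`: 0.7 nM
- compound 3, `C=CCN1CCN(c2ccc(C(=O)Nc3n[nH]c4nc(-c5c(Cl)c(OC)cc(OC)c5Cl)ccc34)cc2)CC1`: 3.3 nM

All three compounds share one core and differ only in the group on the ring nitrogen of the 4-methylpiperazin-1-yl unit. In a functional assay on NCI-H1581 cells (Homo sapiens) for antiproliferative activity, read by CCK-8 assay, with a stated time of 72 h (a higher number here means a weaker inhibitor, a lower number a stronger inhibitor), compound 1 sits second highest of the three numbers. The step of a 2.4-fold lower number from compound 1 to compound 2 (0.39 log units; beyond the scatter) is beyond the scatter, while a 1.9-fold higher number from compound 1 to compound 3 (0.29 log units; within the scatter) stays within it, and a 4.7-fold higher number from compound 2 to compound 3 (0.67 log units; beyond the scatter) is the largest step seen.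

Compound 4, `COc1cc(OC)c(Cl)c(-c2ccc3c(NC(=O)c4ccc(N5CCN(C(C)=O)CC5)cc4)n[nH]c3n2)c1Cl`, is the next compound. Its change from compound 1 is acetyl in place of methyl on an amine nitrogen in a ring.

Every measured step also touches this same ring nitrogen, and each moved the number by only a modest amount in either direction. An acetyl group is a larger departure than any of those, so a modest rise in the number is expected, the step of a 2.9-fold higher number from compound 1 to compound 4 (0.47 log units; beyond the scatter) being the estimate. For compound 4 the expected value is 5 nM, with a range from 1.5 nM to 20 nM.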

Compound 4, half-maximal inhibitory concentration: 43.3 nM
Compound 4: middle estimate off by 8.7-fold (0.94 log units), on the low side; the whole stated range lies below it.
By their numbers in this assay, from the lowest: compound 2; then compounds 1 and 3 (each within the scatter of the next); then compound 4.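

Methyl, ethyl and allyl on this ring nitrogen differ by modest steps at most, but in this assay acetyl, which adds a carbonyl and one hydrogen-bond acceptor, gives a 25-fold higher number from compound 1 to compound 4 (1.41 log units; beyond the scatter). The same large rise appears against the other two groups, with a 13-fold higher number from compound 3 to compound 4 (1.12 log units; beyond the scatter) and a 62-fold higher number from compound 2 to compound 4 (1.79 log units; beyond the scatter), so this position responds far more strongly to the swap from an alkyl group to acetyl than to any change among the alkyl groups. No measurement available here explains the rise.

From the compounds shown here alone, it remains open whether the rise belongs to acetyl alone or extends to other groups joined through a carbonyl, such as benzoyl or a urea. A methylsulfonyl group, or a longer chain ending in an amine, on the same nitrogen would show how far the effect reaches beyond these four compounds.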